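The source may report more compounds than this note shows. Statements on the series, on what has been measured and on what is new or still open speak of the compounds shown alone.

Working notes on the series, step from compound 3 to compound 4.

The shared core carries a substituted acylhydrazone arm, and three members have numbers in a functional assay on U-87MG ATCC cells (Homo sapiens) for cytotoxicity, read by MTT assay, with a stated time of 72 h (on this read-out lower numbers stand for stronger inhibition and higher numbers for weaker inhibition), so far. Compound 1 `CN(C)CCn1cnnc1-c1cc(Oc2ccc(NC(=O)N/N=C/c3c[nH]c4ccccc34)cc2F)ccn1` gives 690 nM in this assay. Compound 2 `CN(C)CCn1cnnc1-c1cc(Oc2ccc(NC(=O)N/N=C/c3ccc(O)c(Br)c3)cc2F)ccn1` gives 12400 nM. Compound 3 `CN(C)CCn1cnnc1-c1cc(Oc2ccc(NC(=O)N/N=C/c3cccc(Br)c3)cc2F)ccn1` gives 830 nM and stands second highest of the three, with compound 1 nearest, as the step of a 1.2-fold higher number from compound 1 to compound 3 (0.08 log units; within the scatter) shows, and compound 2 furthest, as the step of a 15-fold lower number from compound 2 to compound 3 (1.17 log units; beyond the scatter) shows. The one large movement recorded so far is an 18-fold higher number from compound 1 to compound 2 (1.25 log units; beyond the scatter), and its counterpart a 15-fold lower number from compound 2 to compound 3 (1.17 log units; beyond the scatter), so the arm is not indifferent, but the exchange of indol-3-yl for 3-bromophenyl leaves the number essentially unchanged.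

Compound 4 `CN(C)CCn1cnnc1-c1cc(Oc2ccc(NC(=O)N/N=C/c3ccc(Cl)cc3)cc2F)ccn1` differs from compound 3 by 4-chlorophenyl in place of 3-bromophenyl on a carbon with a double bond to nitrogen. Within the data shown here, no measured step swaps one halogen-bearing phenyl for another; the nearest guide is the small step of a 1.2-fold higher number from compound 1 to compound 3 (0.08 log units; within the scatter), where a different aryl group on the same carbon changed little. For compound 4 the step of a 1.1-fold higher number from compound 3 to compound 4 (0.04 log units; within the scatter) is therefore expected to stay within the scatter in this assay. The estimate for compound 4 is 900 nM, with a range from 350 nM to 2500 nM.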

Compound 4, half-maximal inhibitory concentration: 1370 nM
The estimate for compound 4 lay 1.5-fold (0.18 log units) below the measured number, and the stated range covers the measured number.
By their numbers in this assay, from the lowest: compounds 1, 3 and 4 (each within the scatter of the next); then compound 2.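

In this assay, the exchange of 3-bromophenyl for 4-chlorophenyl on the carbon with a double bond to nitrogen stays within the scatter (a 1.7-fold higher number from compound 3 to compound 4 (0.22 log units; within the scatter)), so this position accepts a halogen-bearing phenyl with a different halogen and a different substitution pattern without a readable shift. The comparison with the indole arm also stays within the scatter (a 2.0-fold higher number from compound 1 to compound 4 (0.30 log units; within the scatter)), which places three different aryl groups in one band, while compound 2 stands apart from this new member as well (a 9.1-fold lower number from compound 2 to compound 4 (0.96 log units; beyond the scatter)), making 3-bromo-4-hydroxyphenyl the only arm of the four that separates from the others beyond the scatter. No supporting measurement bears on what lies behind this tolerance or behind the separate standing of compound 2.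

The step from compound 3 to compound 4 changes the halogen and its place on the ring together, so the compounds shown cannot separate the two, and 3-chlorophenyl or 4-bromophenyl would be needed to do so. Going by these compounds, it also remains open whether a 4-hydroxyphenyl arm without bromine, or a 4-aminophenyl arm, would fall with compound 2 or with the other three.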